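The source may report more compounds than this note shows. Statements on the series, on what has been measured and on what is new or still open speak of the compounds shown alone.

Measured so far:
Compound 1, `CCC(Sc1nc2c(cnn2C)c(=O)n1-c1ccccc1)c1ccccc1`, with 150 nM in an assay on isolated protein for inhibition of aldehyde dehydrogenase 1A1 (Homo sapiens); on this read-out higher numbers stand for weaker inhibition and lower numbers for stronger inhibition.
Compound 2, `CC(Sc1nc2c(cnn2C)c(=O)n1-c1ccccc1)c1cccc(O)c1`, with 130 nM in this assay.

Among these two numbers, compound 2 has the lowest value, but its gap to compound 1 is small: a 1.2-fold lower number from compound 1 to compound 2 (0.06 log units; within the scatter). Those two values therefore tell of no real difference between the compounds, and compound 2 cannot be called the stronger of the two.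

The next compound is compound 3, `CC(Sc1nc2c(cnn2C)c(=O)n1-c1ccccc1)c1ccccc1`. It keeps the shared core and the methyl-bearing link on the sulfur of compound 2 and differs only in one spot: hydrogen in place of hydroxy on an aromatic carbon. Going by the values given here, the only measured step that bears on this change is the one from compound 1 to compound 2, in which the whole group on the sulfur was exchanged, including the arrival of the hydroxy, and the number hardly moved. Taking the hydroxy away again is thus expected to leave the number close to where it is, with no step beyond the scatter in either direction: a 1.2-fold higher number from compound 2 to compound 3 (0.06 log units; within the scatter). For compound 3 the expected value in this assay is 150 nM, within a range from 70 nM to 320 nM.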

Compound 3, half-maximal inhibitory concentration: 130 nM
The estimate for compound 3 lay 1.2-fold (0.06 log units) above the measured number; the measured number falls inside the stated range.
By their numbers in this assay, from the lowest: compounds 2, 3 and 1 (each within the scatter of the next).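

In this assay, exchanging 3-hydroxyphenyl for phenyl gives no change at the digits printed from compound 2 to compound 3 (within the scatter), and this isolates the hydroxy on its aromatic carbon, whereas the earlier step exchanged the whole group on the sulfur at once. The second single change, hydrogen in place of methyl on a saturated chain carbon, gives a 1.2-fold lower number from compound 1 to compound 3 (0.06 log units; within the scatter), so each of the two changes folded into the earlier step can now be read alone, and neither shows a real difference in this read-out. Nothing measured here explains why the number stays put at either place.

On these data alone, whether an amine, a carboxylic acid or a methoxy group on that same aromatic carbon would also leave the number within the scatter remains open, since a single hydroxy says little about other groups there. Also open is what a longer chain, such as propyl or butyl, would do on the saturated carbon, where the compounds shown stop at the methyl group that separates compound 1 from compound 3.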